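Cyclopropyl for propyl on the pyridinone side chain

The source may hold more compounds than are shown below. What is called first, only, known or untested is meant among the compounds shown, and "the series" means these compounds.

Compound 1 `Cc1ncccc1Oc1ccc(-c2ccn(CC3CC3)c(=O)c2C#N)cc1` — 155%
Compound 2 `CCCCn1ccc(-c2ccc(Oc3cccnc3C)c(Cl)c2)c(C#N)c1=O` — 236%

Of the compounds shown here, two have been measured in a functional assay on CHO cells for positive allosteric modulation of metabotropic glutamate receptor 2 (Homo sapiens), read by scintillation counting and GTPgammaS binding, with a stated time of 30 min; on this read-out lower numbers stand for smaller maximal responses and higher numbers for larger maximal responses. Compound 2 stands highest of the two, and its distance from compound 1 lies beyond the scatter of this measurement. Compound 3 `Cc1ncccc1Oc1ccc(-c2ccn(CC3CC3)c(=O)c2C#N)cc1Cl` has not been measured. It differs from compound 2 in one place: cyclopropyl in place of propyl on a saturated chain carbon bound to an aromatic nitrogen. Among the measured compounds shown here, no step between measured compounds isolates this change, so its size is not known from the data. In this assay the same chain as in compound 3 is carried by compound 1, which gives 155%, although compound 1 and compound 3 also differ elsewhere. A moderate decrease from compound 2 to compound 3 is expected, a number 41 percentage points lower from compound 2 to compound 3 (beyond the scatter), likely beyond the scatter. Compound 3 is therefore estimated at 195%, with a range from 145% to 245%.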

Compound 3, largest response reached (Emax), in percent of the reference or control that the assay uses: 180%
Beside the measured number, compound 3's estimate is 15 percentage points above it; the range from low to high includes it.
By their numbers in this assay, from the lowest: compound 1; then compound 3; then compound 2.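

In this assay, cyclopropyl in place of propyl on a saturated chain carbon bound to an aromatic nitrogen gives a number 56 percentage points lower from compound 2 to compound 3 (beyond the scatter) with the chloro group present in both compounds, so the chain change now has a measured size of its own. Chloro in place of hydrogen on an aromatic carbon gives a number 25 percentage points higher from compound 1 to compound 3 (beyond the scatter) with the chain held the same, so the two places that separate compound 1 from compound 2 now each have their own step, and the two steps run in opposite directions. Nothing at hand gives a reason for either step.

On these data alone, whether the chloro step keeps its size with the butyl chain stays open. So does the reading in this assay for a longer chain such as pentyl, or for fluoro in place of chloro.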